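Sigma-2 binding: swapping the piperazine tail of compound 1

The source may report more compounds than this note shows. Statements on the series, on what has been measured and on what is new or still open speak of the compounds shown alone.

Measured compounds:
- compound 1 `Cc1cccc2sc(NC(=O)CCN3CCN(CCCN(C)C)CC3)nc12`: > 1000 nM
- compound 2 `CCCCCCN1CCN(CCC(=O)Nc2nc3c(C)cccc3s2)CC1`: 158 nM
- compound 3 `Cc1cccc2sc(NC(=O)CCN3CCN(C4CCN(C)CC4)CC3)nc12`: 3600 nM

In an assay on membranes from liver for displacement of a labelled ligand from Sigma intracellular receptor 2 (Rattus norvegicus), read by scintillation counting, with a stated time of 120 min (a higher number here means a weaker inhibitor, a lower number a stronger inhibitor), compound 1 gives only a limit, > 1000 nM, so its true number is not known. Compound 2 gives 158 nM in this assay, and compound 3 gives 3600 nM. The step of an at least 6.3-fold lower number from compound 1 to compound 2 (0.80 log units; beyond the scatter) is the only readable one; the step that the limit leaves unreadable from compound 1 to compound 3 cannot be sized because of the limit of > 1000 nM in this assay, at which 1 of the 3 values shown sits.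

Compound 4 `Cc1cccc2sc(NC(=O)CCN3CCN(c4ccncc4)CC3)nc12` differs from compound 1 by pyridin-4-yl in place of 3-(dimethylamino)propyl on an amine nitrogen in a ring. Among the compounds with values here, no measured step covers an aromatic group at this nitrogen, so the expectation rests loosely on compound 1 and compound 3. Compound 4 is expected to give about 2000 nM (range 300 nM to 10000 nM) in this assay, which means an estimated step that the limit leaves unreadable from compound 1 to compound 4.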

Compound 4, inhibition constant: 1700 nM
The estimate for compound 4 lay 1.2-fold (0.07 log units) above the measured number; measured number inside the range.
By their numbers in this assay, from the lowest: compound 2; then compound 4; then compound 3.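

Pyridin-4-yl puts an aromatic ring on this amine nitrogen, and replacing 1-methylpiperidin-4-yl with it gives a 2.1-fold lower number from compound 3 to compound 4 (0.33 log units; beyond the scatter). Even so, the aromatic ring does not match the hexyl chain, with an 11-fold higher number from compound 2 to compound 4 (1.03 log units; beyond the scatter). The step from compound 1 to compound 4 cannot be read: the limit of > 1000 nM in this assay, at which 1 of the 4 values shown sits.

Open, from the compounds shown here alone, is how a phenyl ring, with no ring nitrogen, or a longer chain such as octyl would compare at this amine nitrogen. Also open, going by these compounds, is whether a pyridin-2-yl ring would give a different number from pyridin-4-yl.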